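A Stereocentre Redrawn in Compound 3

The source may report more compounds than this note shows. Statements on the series, on what has been measured and on what is new or still open speak of the compounds shown alone.

Of the compounds shown here, two have so far been measured in a physicochemical assay for lipophilicity, using the shake flask method, measured as octanol-water partition, at pH 7.4; a lower number here means a more polar compound, a higher number a more lipophilic compound. Compound 1 `CCOc1ccc(NC(=O)CC2SCCNC2=O)cc1` gives 1.3. Compound 2 `COc1ccc(NC(=O)[C@H]2SCCNC2=O)cc1` gives 0.9, the lower of the two numbers, and its gap to compound 1 lies beyond the scatter. The next compound to be measured is compound 3 `COc1ccc(NC(=O)[C@@H]2SCCNC2=O)cc1`. The change from compound 2 is the two compounds have the same atoms and bonds and differ only in configuration as drawn: 1 of 1 stereo elements differ; a stereocentre at a saturated ring carbon is drawn S in compound 2 and R in compound 3: a stereocentre at a saturated ring carbon is drawn S in compound 2 and R in compound 3, while the atoms and bonds stay the same. For the measured compounds named here, no measured pair shows such a change. In this assay, no step beyond the scatter is expected in either direction, so the expectation stays with compound 2 at 0.9. The expected step is no change at the digits printed from compound 2 to compound 3 (within the scatter). Compound 3 is estimated at 0.9, with an expected range from 0.6 to 1.2.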

Compound 3, distribution coefficient: 0.8
The estimate for compound 3 lay 0.10 log units above the measured number, within the range that was stated.
By their numbers in this assay, from the lowest: compounds 3 and 2 (each within the scatter of the next); then compound 1.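

In this assay, for the compounds shown here, redrawing the stereocentre at a saturated ring carbon from S to R gives a number 0.10 log units lower from compound 2 to compound 3 (within the scatter), so at this position the inversion brings no step that can be told from the scatter. Going by these compounds alone, this is the first pair that differs in one place, and it gives the first direct reading of any single change, since compound 1 differs from both of the others in more than one place. The reading concerns the stereocentre alone: the fact that compounds 2 and 3 differ only in the configuration as drawn.

From the compounds shown here alone, whether the two configurations stay this close when the shared core carries another group, such as an amine or a carboxylic acid, remains open, as this single pair is all that bears on the point. The compounds shown also leave open whether configuration at this carbon matters in any other kind of measurement.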